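Urea series on a shared core: methoxy for fluoro

The source may hold more compounds than are shown below. What is called first, only, known or untested is meant among the compounds shown, and "the series" means these compounds.

Compound 3 `CC(C)(C)c1cc(NC(=O)Nc2ccc(Nc3ncnc4c3OCCN4)c(F)c2)no1` gives 21 nM in an assay on isolated protein for inhibition of proto-oncogene tyrosine-protein kinase receptor Ret (Homo sapiens), read by 33P incorporation, with stated times of 15 min and 40 min (on this read-out higher numbers stand for weaker inhibition and lower numbers for stronger inhibition), the second highest of three numbers; compound 2 `CC(C)(C)c1cc(NC(=O)Nc2ccc(Nc3ncnc4c3OCCN4)cc2)no1` gives 10 nM and compound 1 `COc1ccc(NC(=O)Nc2ccc(Nc3ncnc4c3OCCN4)cc2)cc1` gives 227 nM. Compound 4 `COc1cc(NC(=O)Nc2cc(C(C)(C)C)on2)ccc1Nc1ncnc2c1OCCN2` differs from compound 3 by methoxy in place of fluoro on an aromatic carbon. Of the two measured steps, a 23-fold lower number from compound 1 to compound 2 (1.36 log units; beyond the scatter) concerns another part of the structure, whereas a 2.1-fold higher number from compound 2 to compound 3 (0.32 log units; beyond the scatter) sits at the same place and was modest. Among the compounds with values here, no measured step exchanges fluoro for methoxy, so for compound 4 only a small step in this assay in either direction, or none beyond the scatter, is expected. Compound 4 is estimated at 25 nM in this assay, range 8 nM to 80 nM, which means a 1.2-fold higher number from compound 3 to compound 4 (0.08 log units; within the scatter) is expected.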

Compound 4, half-maximal inhibitory concentration: 22 nM
Estimate against measurement, compound 4: 1.1-fold (0.06 log units) above, within the range that was stated.
By their numbers in this assay, from the lowest: compound 2; then compounds 3 and 4 (each within the scatter of the next); then compound 1.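

At this aromatic carbon, ortho to a large group and meta to a large group, a 1.0-fold higher number from compound 3 to compound 4 (0.02 log units; within the scatter) lies within the scatter, so methoxy and fluoro cannot be told apart in this assay here. Set against hydrogen, methoxy gives a 2.2-fold higher number from compound 2 to compound 4 (0.34 log units; beyond the scatter) and stays a modest step, so this position tolerates a group of two heavy atoms. No measurement shown accounts for either step.

Open, going by these compounds, is whether ethoxy or a dimethylamino group at this carbon holds the same level. Also open, on these data alone, is whether methoxy here behaves alike with the 4-methoxyphenyl urea of compound 1.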